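Removing the Bromo Group from Compound 1

This account rests on a few compounds, and the source may have more. Where it says the series, first, only, none or still open, it means among the compounds named here.

compound 1 `NCCCNc1c(C(=O)NCc2ccc(F)cc2)nc(Br)c2cccnc12` gives 18000 nM
compound 2 `C[C@H](Nc1c(C(=O)NCc2ccc(F)cc2)nc(Br)c2cccnc12)c1ccccc1` gives > 20000 nM

In a functional assay on HCT-116 cells (Homo sapiens) for cytotoxicity, read by MTT assay, with a stated time of 72 h (on this read-out lower numbers stand for stronger inhibition and higher numbers for weaker inhibition), compound 1 gives 18000 nM as the only number shown. Compound 2 reaches only the limit of > 20000 nM and gives no number. Compound 3 (`NCCCNc1c(C(=O)NCc2ccc(F)cc2)ncc2cccnc12`) arises through hydrogen in place of bromo on an aromatic carbon with hydrogen in place of bromo on an aromatic carbon. For the measured compounds named here, the one measured step (an at least 1.1-fold higher number from compound 1 to compound 2 (0.04 log units; that floor lies within the scatter)) sits at another place, on a nitrogen, so it bears only weakly on this change. An estimated (a 1.1-fold lower number from compound 1 to compound 3 (0.05 log units; within the scatter)) stays within the scatter, so no clear step is expected in this assay in either direction. Compound 3 is expected at 16000 nM (6000 nM to 30000 nM).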

Compound 3, half-maximal inhibitory concentration: > 10000 nM
Compound 3 gave a limit, no number; the forecaster's own chance of this, stated with the estimate: 40%; the middle value lies beyond the limit too.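

For the compounds shown here, compound 3 gives only a limit, > 10000 nM, so no step from compound 1 to compound 3 can be read. The compounds shown leave open whether hydrogen in place of bromo shifts the number in either direction.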